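This account rests on a few compounds, and the source may have more. Where it says the series, first, only, none or still open, it means among the compounds named here.

Measured in a functional assay on LNCaP cells (Homo sapiens) for antiproliferative activity, read by WST assay, with a stated time of 3 days; a higher number here means a weaker inhibitor, a lower number a stronger inhibitor:
- Compound 1 `CCCCCCCOc1c(-c2cc(OC)c(OC)c(OC)c2)oc2ccccc2c1=O`: > 50000 nM, a limit of the assay
- Compound 2 `CCN(CC)CCCCCOc1c(-c2cc(OC)c(OC)c(OC)c2)oc2ccccc2c1=O`: 10000 nM
- Compound 3 `CCCCCN(CCCCC)CCCCOc1c(-c2cc(OC)c(OC)c(OC)c2)oc2ccccc2c1=O`: 9700 nM

Among the measured compounds shown here, compound 3, at 9700 nM, cannot be told apart from the only other exact number: a 1.0-fold lower number from compound 2 to compound 3 (0.01 log units; within the scatter). That step put dipentylamino in place of (diethylamino)methyl.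

Compound 4 `CCCCCN(CCCCC)CCCCCOc1c(-c2cc(OC)c(OC)c(OC)c2)oc2ccccc2c1=O` has (dipentylamino)methyl in place of dipentylamino on a saturated chain carbon, four bonds along the chain from an oxygen on an aromatic ring. Two other steps introduced an amino group: an at least 5.0-fold lower number from compound 1 to compound 2 (0.69 log units; beyond the scatter) and an at least 5.1-fold lower number from compound 1 to compound 3 (0.71 log units; beyond the scatter). Compound 4 keeps that group, so those steps give no reason to expect a return to the limit. The closest guide is the step from (diethylamino)methyl to dipentylamino, which stayed within the scatter. The expected change is a 1.1-fold lower number from compound 3 to compound 4 (0.03 log units; within the scatter), which would lie within the scatter. Compound 4 is estimated at 9000 nM, with an expected range of 3500 nM to 25000 nM.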

Compound 4, half-maximal inhibitory concentration: 7900 nM
Estimate against measurement, compound 4: 1.1-fold (0.06 log units) above, and the stated range covers the measured number.
By their numbers in this assay, from the lowest: compounds 4, 3 and 2 (each within the scatter of the next). At a limit, above all of these: compound 1.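

In this assay, (dipentylamino)methyl in place of dipentylamino cannot be told apart from repeat scatter, with a 1.2-fold lower number from compound 3 to compound 4 (0.09 log units; within the scatter). With the chain length held, dipentylamino in place of diethylamino is no clearer, with a 1.3-fold lower number from compound 2 to compound 4 (0.10 log units; within the scatter), so the alkyl groups on the amine are not separated at this length either. The step from the chain without an amine, an at least 6.3-fold lower number from compound 1 to compound 4 (0.80 log units; beyond the scatter), rests on a limit of the assay and is only a bound: the limit of > 50000 nM in this assay, at which 1 of the 4 values shown sits.

As far as these compounds go, whether a ring amine such as piperidine, or a much shorter chain carrying dimethylamino, would give a number beyond the scatter of these three amines stays open.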